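Trifluoromethoxyphenyl sulfonamide: estimating potency from compound 1

A few compounds are considered here, and "the series" means these few. Any claim that something is new, unique, unknown or untested is made for them only; others in the source may bear on it.

Measured so far in a functional assay on Umbilical vein for antagonist activity at B1 bradykinin receptor (Homo sapiens), using Schild analysis, with a stated time of 30 min; on this read-out higher numbers stand for higher potency (the scale is a negative logarithm) and lower numbers for lower potency:
- compound 1 `COc1ccc(S(=O)(=O)N(C)CCOCC(=O)N(C)Cc2ccc(C3=NCCN3)cc2)c(C)c1`: 8.6
- compound 2 `COc1cc(C)c(S(=O)(=O)N(C)CCOCC(=O)N2CCC(C3CCN(C)CC3)CC2)c(C)c1`: 9
- compound 3 `COc1cc(C)c(S(=O)(=O)N(C)CCOCC(=O)N2CCN(C3CCN(C4CC4)CC3)CC2)c(C)c1`: 8.5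

Among these three, compound 1 and compound 3 give numbers that fall within the usual scatter of each other, while compound 2 lies above compound 1 by an amount beyond that scatter. Compound 4 `CN(Cc1ccc(C2=NCCN2)cc1)C(=O)COCCN(C)S(=O)(=O)c1ccc(OC(F)(F)F)cc1` is not yet measured. It differs from compound 1 in one place: 4-(trifluoromethoxy)phenyl in place of 4-methoxy-2-methylphenyl on a sulfonyl sulfur. For the measured compounds named here, no measured pair shows this exact change, so its effect can only be guessed. The expectation is a modest shift, a number 0.20 log units lower from compound 1 to compound 4 (within the scatter), with the chance of no change beyond the scatter remaining real. For compound 4 the estimated result in this assay is 8.4, between 7.8 and 9.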

Compound 4, negative logarithm of the antagonist equilibrium constant: 7.5
Estimate against measurement, compound 4: 0.90 log units above; measured number below the stated range.
By their numbers in this assay, from the lowest: compound 4; then compounds 3 and 1 (each within the scatter of the next); then compound 2.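

In this assay, the group on a sulfonyl sulfur proves to matter: 4-(trifluoromethoxy)phenyl in place of 4-methoxy-2-methylphenyl gives a number 1.10 log units lower from compound 1 to compound 4 (beyond the scatter) and so is a large step. For the compounds shown here, no earlier pair of compounds differing in one place had tested this position. Nothing available accounts for this loss.

From the compounds shown here alone, this single change alters both the methyl group and the methoxy group, so the contribution of each remains open. A plain 4-methoxyphenyl or 4-(trifluoromethyl)phenyl group at this place would help separate them.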